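The source may report more compounds than this note shows. Statements on the series, on what has been measured and on what is new or still open speak of the compounds shown alone.

Measured compounds:
compound 1 `O=C(NCc1cc(Cl)ccc1-n1cnnn1)[C@@H]1CC=NN1C(=O)[C@H](O)c1ccccc1F` — 1100 nM
compound 2 `O=C(NCc1cc(Cl)ccc1-n1cnnn1)[C@@H]1C[C@H]2C[C@H]2N1C(=O)[C@H](O)c1cccc(F)c1` — 1100 nM
compound 3 `O=C(NCc1cc(Cl)ccc1-n1cnnn1)[C@@H]1C[C@@H]2C[C@@H]2N1C(=O)[C@H](O)c1ccccc1F` — 770 nM

Of the compounds shown here, three sharing one core have been tested in a functional assay on a cell-free system (plasma, Homo sapiens), with a stated time of 3 min; on this read-out higher numbers stand for weaker inhibition and lower numbers for stronger inhibition. Compound 1 gives 1100 nM in this assay, and compound 2 gives 1100 nM, so at the digits recorded the two stand level and together hold the highest numbers of the three. Compound 3 gives 770 nM in this assay; its number is somewhat lower than that of compound 2, but the gap falls within the usual scatter of such measurements, so no order among the three can be stated. Among the measured compounds shown here, no paired step between measured compounds is available from which the weight of a single change could be read.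

Compound 4 `CC1(C[C@@H](O)C(=O)N2[C@@H]3C[C@@H]3C[C@H]2C(=O)NCc2cc(Cl)ccc2-n2cnnn2)CC1` has not yet been measured. It differs from compound 2 in one place: (1-methylcyclopropyl)methyl in place of 3-fluorophenyl on a saturated chain carbon bound to a carbonyl carbon and an oxygen on a saturated carbon. Nothing in the measured set shows how an aromatic group gives way to a small saturated one at this carbon, so the expectation rests on the change itself. The step is expected to be a modest rise in the number, a 2.7-fold higher number from compound 2 to compound 4 (0.44 log units; beyond the scatter), meaning somewhat weaker inhibition in this assay, though a result within the scatter would not surprise. For compound 4 the expected value in this assay is 3000 nM, with a range from 800 nM to 12000 nM.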

Compound 4, half-maximal inhibitory concentration: 1300 nM
Beside the measured number, compound 4's estimate is 2.3-fold (0.36 log units) above it; the measured number falls inside the stated range.
By their numbers in this assay, from the lowest: compounds 3, 1, 2 and 4 (each within the scatter of the next).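

Among the compounds shown here, measured in this assay, the exchange of 3-fluorophenyl for (1-methylcyclopropyl)methyl on a saturated chain carbon bound to a carbonyl carbon and an oxygen on a saturated carbon gives a 1.2-fold higher number from compound 2 to compound 4 (0.07 log units; within the scatter) and is the first paired step in the set, so the weight of a single change at this position can now be read. In this one pair, a group with one six-membered aromatic ring of carbon only and a fluorine gives way to one with a three-membered non-aromatic ring of carbon only and fewer heavy atoms, and the read-out stays within the scatter, which shows that an aromatic ring is not required at this position to keep the number at the level of compound 2. No supporting measurement bears on why the two groups read alike.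

On these data alone, this rests on a single pair, so it remains open whether other groups at this carbon, such as a longer chain, an amine or a carboxylic acid, would also leave the number within the scatter. As far as these compounds go, it is also open whether the same exchange would read alike on the core of compound 1 or with the fluorine placement of compound 3.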